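The source may hold more compounds than are shown below. What is called first, only, known or untested is meant among the compounds shown, and "the series" means these compounds.

Notes on a small series sharing one core, tested in a functional assay on MCF7 cells (Homo sapiens) for cytotoxicity, read by MTT assay, with a stated time of 72 h; on this read-out lower numbers stand for stronger inhibition and higher numbers for weaker inhibition. Compound 1 (`COc1cccc(/C=C2\CCC/C(=C\c3cc(Cl)cc(Cl)c3)C2=O)c1OC`) gives 4300 nM, compound 2 (`COc1ccc(/C=C2\CCC/C(=C\c3cccc(OC)c3OC)C2=O)cc1OC`) gives 6500 nM and compound 3 (`COc1ccc(/C=C2\CCC/C(=C\c3ccccc3Cl)C2=O)cc1OC`) gives 10400 nM. Compound 3 lies within the scatter of compound 2, and its number is higher than that of compound 1 by a gap beyond the scatter.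

Compound 4 (`COc1ccc(/C=C2\CCC/C(=C\c3ccc(OC)c(OC)c3)C2=O)cc1`) is still unmeasured. It differs from compound 3 in one place: 4-methoxyphenyl in place of 2-chlorophenyl on a double-bonded chain carbon bound to a double-bonded ring carbon, with 4-methoxyphenyl in place of 2-chlorophenyl on a double-bonded chain carbon bound to a double-bonded ring carbon.

Among the measured compounds shown here, no measured pair differs in a single place, so the series gives no direct guide to this change. Like compound 4, compound 2 carries no chlorine and gives 6500 nM, whereas compound 1 does carry chlorine and gives 4300 nM, so chlorine alone does not sort these values. In this assay, no step beyond the scatter is expected, and any small shift would more likely be toward a lower number. The estimated step of a 1.4-fold lower number from compound 3 to compound 4 (0.14 log units; within the scatter) therefore stays within the scatter. For compound 4 the estimate is 7500 nM, with an expected range of 3000 nM to 18000 nM.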

Compound 4, half-maximal inhibitory concentration: 7800 nM
Compound 4: the middle estimate sits 1.0-fold (0.02 log units) below what was measured; measured number inside the range.
By their numbers in this assay, from the lowest: compounds 1, 2, 4 and 3 (each within the scatter of the next, the first and the last beyond it).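

In this assay, among the compounds shown here, 4-methoxyphenyl in place of 2-chlorophenyl on a double-bonded chain carbon bound to a double-bonded ring carbon gives a 1.3-fold lower number from compound 3 to compound 4 (0.12 log units; within the scatter), which is the first single-place comparison available. At this position, the exchange removes the chlorine and adds one hydrogen-bond acceptor without a change that this read-out can separate from the scatter, so these two phenyl groups are not told apart here. No supporting measurement bears on this result.

From the compounds shown here alone, whether an amine or a carboxylic acid on the phenyl ring at this position would give a step beyond the scatter remains open. Also open, going by these compounds, is whether the same exchange would stay within the scatter if the group at the other end of the shared core were different.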